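Amide for Acid on Two Related Cores

The source may report more compounds than this note shows. Statements on the series, on what has been measured and on what is new or still open speak of the compounds shown alone.

In a functional assay on HCT-116 cells (Homo sapiens) for inhibition, read by MTT assay, with a stated time of 72 h (on this read-out lower numbers stand for stronger inhibition of growth and higher numbers for weaker inhibition of growth), compound 3 `O=C(O)CCc1ccncc1-c1ccc2ccccc2c1` gives only a limit, > 30000 nM. Compound 2 `CNC(=O)CCc1ccncc1-c1ccc2ccccc2c1` arises from the change methylamino in place of hydroxy on a carbonyl carbon and gives 19300 nM, so the step reads an at least 1.5-fold lower number from compound 3 to compound 2 (0.19 log units; that floor lies within the scatter). That step is only a floor because the limit of > 30000 nM in this assay, at which 2 of the 3 values shown sit, is where compound 3 sits. Compound 1 `Cn1ncc2cc(-c3cnccc3/C=C/C(=O)O)ccc21` has a different core; the difference between the two cores is not broken down here. In this assay compound 1 gives only a limit, > 30000 nM. Compound 4 `CNC(=O)/C=C/c1ccncc1-c1ccc2c(cnn2C)c1` carries the same kind of change, (methylamino in place of hydroxy on a carbonyl carbon), though here the carbonyl carbon's other neighbour is a double-bonded chain carbon rather than a saturated chain carbon. Resting on an at least 1.5-fold lower number from compound 3 to compound 2 (0.19 log units; that floor lies within the scatter), the expected step for compound 4 is an at least 1.3-fold lower number from compound 1 to compound 4 (0.13 log units; that floor lies within the scatter). The estimate for compound 4 is 22000 nM, with a fair chance that only a limit comes back.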

Compound 4, concentration for 50% growth inhibition: 3480 nM
For compound 4 the middle estimate is 6.3-fold (0.80 log units) above the measured one; measured number below the stated range.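

Putting methylamino in place of hydroxy on the carbonyl carbon gives an at least 8.6-fold lower number from compound 1 to compound 4 (0.93 log units; beyond the scatter) in this assay, so on the core of compound 1 the change clearly counts. A real gain is therefore shown on this core only, and the change is not shown to be worth the same amount on the two cores. Both steps start from an acid that gives only a limit, and their sizes cannot be compared: the same change on two cores in this assay, an at least 1.5-fold lower number (0.19 log units; that floor lies within the scatter) from compound 3 to compound 2 and an at least 8.6-fold lower number (0.93 log units; beyond the scatter) from compound 1 to compound 4; the limit leaves it open whether they differ

Going by these compounds, what a plain amino or a dimethylamino group on the same carbonyl carbon would give on either core remains open. The compounds shown also hold no pair that differs only in having a double-bonded or a saturated chain.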